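A few compounds are considered here, and "the series" means these few. Any claim that something is new, unique, unknown or untested is made for them only; others in the source may bear on it.

Values so far in a physicochemical assay for solubility, read by HPLC, at pH 2; a lower number here means a less soluble compound, a higher number a more soluble compound:
- compound 1 `Cc1cc(C#N)cc(C)c1Oc1cc(Nc2ccc(C#N)cc2)c(N)cc1CO`: 9.12 ug/mL
- compound 2 `CNCc1cc(N)c(Nc2ccc(C#N)cc2)cc1Oc1c(C)cc(C#N)cc1C`: 263 ug/mL
- compound 3 `CC(=O)OCc1cc(N)c(Nc2ccc(C#N)cc2)cc1Oc1c(C)cc(C#N)cc1C`: 16.7 ug/mL

Compound 3 lies close to compound 1 and far from compound 2. Two steps set that position: a 1.8-fold higher number from compound 1 to compound 3 (0.26 log units; within the scatter), and a 16-fold lower number from compound 2 to compound 3 (1.20 log units; beyond the scatter).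

Compound 4 `CC(=O)OCc1cc(N)c(Nc2ccc(C#N)cc2)cc1Oc1c(C)cc(CCC#N)cc1C` differs from compound 3 in one place: 2-cyanoethyl in place of cyano on an aromatic carbon. Here 2-cyanoethyl stands in place of cyano on an aromatic carbon.

Going by the values given here, no measured step touches this place. All three concern the group on the saturated chain carbon. The large ones, a 29-fold higher number from compound 1 to compound 2 (1.46 log units; beyond the scatter) and the step from compound 2 already given, both involve methylamino, which compound 4 does not carry. They give no guide to size here. Among the compounds with values here, the only step without methylamino stays within the scatter: a 1.8-fold higher number from compound 1 to compound 3 (0.26 log units; within the scatter). In this assay, no step beyond the scatter is therefore expected, and the direction is open.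

The estimate for compound 4 is 14 ug/mL, with an expected range of 6 ug/mL to 32 ug/mL. This estimate means a 1.2-fold lower number from compound 3 to compound 4 (0.08 log units; within the scatter).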

Compound 4, solubility: 2.63 ug/mL
Estimate against measurement, compound 4: 5.3-fold (0.73 log units) above; measured number below the stated range.
By their numbers in this assay, from the lowest: compound 4; then compounds 1 and 3 (each within the scatter of the next); then compound 2.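

In this assay this aromatic carbon, meta to two methyl groups and para to a large group, turns out not to be a silent place: 2-cyanoethyl in place of cyano gives a 6.3-fold lower number from compound 3 to compound 4 (0.80 log units; beyond the scatter) on the acetoxy background. Going by these compounds alone, it is the first step read at this place rather than on the saturated chain carbon, and the first beyond the scatter that does not involve methylamino. No measured data bear on the reason for this step.

From the compounds shown here alone, the step rests on a single pair, so it remains open whether it carries over to the compounds with hydroxy or methylamino on the saturated chain carbon. Also open, going by these compounds, is how a longer nitrile chain, an amine or a carboxylic acid on this aromatic carbon would read in this assay against cyano and 2-cyanoethyl.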